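The source may report more compounds than this note shows. Statements on the series, on what has been measured and on what is new or still open speak of the compounds shown alone.

Measured so far:
- compound 1 `COc1cc(OC)cc(-c2cccc(NC(=O)CCc3ccc4c(c3)B(O)OC4)c2)c1` gives > 100000 nM (a limit of the assay)
- compound 2 `COc1cccc(-c2cccc(NC(=O)CCc3cccc4c3COB4O)c2)c1` gives > 100000 nM (a limit of the assay)

Both entries come from an ADME assay on WI-38 cells (Homo sapiens) for cytotoxicity, read by MTT assay, with a stated time of 72 h; on this read-out lower numbers stand for stronger inhibition and higher numbers for weaker inhibition. Compound 2 has no numerical value here, only the limit > 100000 nM. The one other result, for compound 1, is also a limit and not a number. Going by the values given here, the series so far shows (the limit of > 100000 nM in this assay, at which 2 of the 2 values shown sit), so neither compound can be ranked against the other.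

The next compound is compound 3 `COc1cc(OC)cc(-c2cccc(NC(=O)CCc3cccc4c3COB4O)c2)c1`. Its difference from compound 2 is methoxy in place of hydrogen on an aromatic carbon, with methoxy in place of hydrogen on an aromatic carbon, taking 3-methoxyphenyl to 3,5-dimethoxyphenyl.

Among the compounds with values here, no measured step gives a size for this change. The expectation therefore rests on compound 2 at > 100000 nM, and no shift beyond the usual scatter is expected in this assay. The expected change a number no higher from compound 2 to compound 3 (the limit leaves the size open) is small and has no favoured direction. For compound 3 the estimate is 100000 nM, with an expected range from 50000 nM to 150000 nM, and the result is expected to be reported as a limit again.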

Compound 3, half-maximal inhibitory concentration: > 100000 nM
Compound 3: no number, only a limit; the forecaster's own chance of this, stated with the estimate: 90%; the middle value sits exactly at the limit.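

In this assay compound 3 gives > 100000 nM, a limit and not a number. No step from compound 1 or compound 2 to compound 3 can be read, since all three compounds sit at the same limit: the limit of > 100000 nM in this assay, at which 3 of the 3 values shown sit.

The compounds shown leave open whether the methoxy change from compound 2 to compound 3 has any effect in this assay.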